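Adding a Second Chloro to Compound 1

The compounds below may be only part of what the source reports. "The series", "measured", "known", "first", "only" and "open" are said of these compounds alone.

Compound 1 `NC1=NC2(CCSCC2)N(OCCCOc2ccc(Cl)cc2)C(N)=N1` gives 10 nM in a functional assay on HCT-116 cells (Homo sapiens) for antiproliferative activity, read by MTT assay, with a stated time of 72 h (a lower number here means a stronger inhibitor, a higher number a weaker inhibitor), the lower of the two numbers available. Compound 2 `CC(C)(C)c1ccc(OCCCON2C(N)=NC(N)=NC23CCOCC3)cc1` gives 1610 nM in this assay, a gap from compound 1 beyond the usual scatter. Compound 3 `NC1=NC2(CCSCC2)N(OCCCOc2ccc(Cl)c(Cl)c2)C(N)=N1` has not yet been measured. It differs from compound 1 in one place: chloro in place of hydrogen on an aromatic carbon. Within the data shown here, no measured pair shows this change, so only a small step is expected, in either direction, most likely within the scatter. Compound 3 is therefore expected at 12 nM, with a range from 4 nM to 40 nM. This estimate corresponds to an expected step of a 1.2-fold higher number from compound 1 to compound 3 (0.08 log units; within the scatter).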

Compound 3, half-maximal inhibitory concentration: 1 nM
Beside the measured number, compound 3's estimate is 12-fold (1.08 log units) above it, outside the stated range (below it).
By their numbers in this assay, from the lowest: compound 3; then compound 1; then compound 2.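

Going from 4-chlorophenyl to 3,4-dichlorophenyl gives a 10-fold lower number from compound 1 to compound 3 (1.00 log units; beyond the scatter) in this assay. Among these compounds, this shows that a single chloro on this aromatic carbon, ortho to a chloro group and meta to a large group, moves the number beyond the scatter, which no earlier pair could show. Nothing shown gives a reason for this step.

On these data alone, whether chloro is special here stays open, since a fluoro, methyl or methoxy group on the same carbon would test that. As far as these compounds go, whether the step carries over to the core of compound 2 also stays open.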